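Methyl to hydrogen on the aminomethyl nitrogen of the coumarin series

A few compounds are considered here, and "the series" means these few. Any claim that something is new, unique, unknown or untested is made for them only; others in the source may bear on it.

Compound 2 `CNCc1cc(=O)oc2cc(OCc3ccccc3)ccc12` is the lower of the two numbers recorded in an assay for inhibition of Amine oxidase [flavin-containing] B (Rattus norvegicus) (on this read-out lower numbers stand for stronger inhibition and higher numbers for weaker inhibition), where compound 2 gives 28 nM. The nearest measured neighbour is compound 1 `CN(C)C(=O)Cc1cc(=O)oc2cc(OCc3ccccc3)ccc12`, which in this assay gives 400 nM; the step of a 14-fold lower number from compound 1 to compound 2 (1.15 log units; beyond the scatter) is large and well beyond the scatter. Compound 3 `NCc1cc(=O)oc2cc(OCc3ccccc3)ccc12` differs from compound 2 by hydrogen in place of methyl on an amine nitrogen, cut one bond further out: methylamino to amino, (methylamino)methyl to aminomethyl. Going by the values given here, no measured step removes a methyl from an amine nitrogen; the only recorded step, a 14-fold lower number from compound 1 to compound 2 (1.15 log units; beyond the scatter), exchanges a whole dimethylcarbamoyl for methylamino and so does not speak to this change. With nothing comparable to lean on, the expectation for this assay is a step of a 1.8-fold higher number from compound 2 to compound 3 (0.25 log units; within the scatter), close to no change beyond the scatter, with a wide margin. Compound 3 is therefore estimated at 50 nM, within 15 nM to 200 nM.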

Compound 3, half-maximal inhibitory concentration: 21 nM
Compound 3: the middle estimate sits 2.4-fold (0.38 log units) above what was measured, and the stated range covers the measured number.
By their numbers in this assay, from the lowest: compounds 3 and 2 (each within the scatter of the next); then compound 1.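

In this assay, hydrogen in place of methyl on the amine nitrogen gives a 1.3-fold lower number from compound 2 to compound 3 (0.12 log units; within the scatter), so compound 2 and compound 3 cannot be told apart and the methyl on this nitrogen is not required for the inhibition recorded here. With amino as with methylamino, the large step from the dimethylcarbamoyl of compound 1 persists, at a 19-fold lower number from compound 1 to compound 3 (1.28 log units; beyond the scatter), and so it does not depend on that methyl. Nothing shown here offers an explanation for either step.

Still open, from the compounds shown here alone, is how far the amine nitrogen accepts more substitution, for example an ethyl group or the second methyl of a dimethylamino group, and whether a longer chain carrying the amine gives the same level of inhibition. Equally open, going by these compounds, is whether the nitrogen itself matters, which a hydroxymethyl group in place of aminomethyl would test.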